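The source may hold more compounds than are shown below. What is called first, only, known or untested is meant among the compounds shown, and "the series" means these compounds.

Three compounds share one core. Compound 1 `COc1ccc(C(=O)NC(CCN(C)C)c2ccc(Cl)cc2)cc1` gives 1350 nM in an assay on NIH3T3 cells with Urotensin-2 receptor (Homo sapiens) as the target; a higher number here means that more compound is needed for the effect, a lower number that less compound is needed. Compound 2 `Cc1ccccc1NC(=O)OC(CCN(C)C)c1ccc(Cl)cc1` gives 3890 nM, and compound 3 `COc1ccc(NC(=O)OC(CCN(C)C)c2ccc(Cl)cc2)cc1` gives 1660 nM. Compound 3 stands second highest of the three numbers; its value and that of compound 1 lie within the scatter of each other, while compound 2 sits above it by a step beyond the scatter, namely a 2.3-fold lower number from compound 2 to compound 3 (0.37 log units; beyond the scatter). Compound 4 `CN(C)CCC(OC(=O)Nc1ccc(-c2ccccc2)cc1)c1ccc(Cl)cc1` differs from compound 3 by phenyl in place of methoxy on an aromatic carbon. Within the data shown here, the only measured step at that part of the structure is the modest one from compound 2 to compound 3, so only a modest shift in this assay is expected for compound 4, in either direction, as a 1.3-fold lower number from compound 3 to compound 4 (0.11 log units; within the scatter). Compound 4 is therefore estimated at 1300 nM, between 400 nM and 4500 nM.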

Compound 4, half-maximal effective concentration: 269 nM
The estimate for compound 4 lay 4.8-fold (0.68 log units) above the measured number; the whole stated range lies above it.
By their numbers in this assay, from the lowest: compound 4; then compounds 1 and 3 (each within the scatter of the next); then compound 2.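

In this assay, phenyl in place of methoxy on this aromatic carbon, para to a large group, gives a 6.2-fold lower number from compound 3 to compound 4 (0.79 log units; beyond the scatter). This position therefore accepts a six-membered aromatic ring of carbon only, and the number still falls even though the hydrogen-bond acceptor of methoxy is gone. No measurement here explains why the number falls.

On these data alone, it remains open whether an amine, a carboxylic acid or a longer chain such as butyl would fare as well at this position. As far as these compounds go, it is also open whether phenyl would lower the number of compound 1 in the same way.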